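The source may hold more compounds than are shown below. What is called first, only, known or untested is meant among the compounds shown, and "the series" means these compounds.

Compound 1 `O=C(CSc1nnnn1-c1ccc(C2CC2)cc1Cl)Nc1ccc(C#CCO)cc1Cl`: 0.117 h
Compound 2 `CC(C)(O)C#Cc1ccc(NC(=O)CSc2nnnn2-c2ccc(C3CC3)cc2Cl)c(Cl)c1`: 1.4 h
Compound 3 `CC(C)(N)C#Cc1ccc(NC(=O)CSc2nnnn2-c2ccc(C3CC3)cc2Cl)c(Cl)c1`: 0.517 h

In an in vitro ADME assay on microsomes from liver (Rattus norvegicus) for metabolic stability, tested at 2 uM (on this read-out higher numbers stand for a longer-lived compound and lower numbers for a shorter-lived compound), compound 3 stands second highest of these three, at 0.517 h. Compound 4 `O=C(O)CC#Cc1ccc(NC(=O)CSc2nnnn2-c2ccc(C3CC3)cc2Cl)c(Cl)c1` has carboxymethyl in place of 1-amino-1-methylethyl on a triple-bonded carbon. For the measured compounds named here, no measured compound carries carboxymethyl, so the evidence is indirect. The nearest measured group is the hydroxymethyl of compound 1, at 0.117 h. Replacing it gave a 12-fold higher number from compound 1 to compound 2 (1.08 log units; beyond the scatter) and a 4.4-fold higher number from compound 1 to compound 3 (0.65 log units; beyond the scatter), while amino in place of hydroxy gave a 2.7-fold lower number from compound 2 to compound 3 (0.43 log units; beyond the scatter). From the compounds shown here alone, these steps suggest a drop, but the new group is untested, so only a small one is expected: the estimated step is a 1.3-fold lower number from compound 3 to compound 4 (0.11 log units; within the scatter). For compound 4 the estimated value is 0.4 h, with an expected range of 0.1 h to 2 h.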

Compound 4, half-life: 0.317 h
Estimate against measurement, compound 4: 1.3-fold (0.10 log units) above; the range from low to high includes it.
By their numbers in this assay, from the lowest: compound 1; then compounds 4 and 3 (each within the scatter of the next); then compound 2.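

In this assay, carboxymethyl in place of 1-amino-1-methylethyl on a triple-bonded carbon gives a 1.6-fold lower number from compound 3 to compound 4 (0.21 log units; within the scatter), so this position accepts the swap without a change that stands out from the scatter. The same group still gives a 2.7-fold higher number from compound 1 to compound 4 (0.43 log units; beyond the scatter) and a 4.4-fold lower number from compound 2 to compound 4 (0.65 log units; beyond the scatter), which places it clearly apart from both hydroxyl-bearing groups. Nothing here gives a measured reason for these steps. Still open, from the compounds shown here alone, is how 1-carboxy-1-methylethyl would read at this position, and whether a methyl ester of the carboxymethyl group would read like the carboxylic acid.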